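The source may hold more compounds than are shown below. What is called first, only, known or untested is meant among the compounds shown, and "the series" means these compounds.

Among the compounds with values here, compound 2 `CC(C)=CCC[C@]1(C)/C=C/[C@@H](OC(=O)C=C(C)C)[C@](C)(O)/C=C/C(=O)/C(CN2CCCC2)=C\C1` gives 140 nM in a functional assay on SMMC-7721 cells (Homo sapiens) for antiproliferative activity, read by MTT assay, with a stated time of 48 h (a lower number here means a stronger inhibitor, a higher number a weaker inhibitor), the lowest of the three numbers measured so far. Compound 1 `CC(=O)OC/C1=C/C[C@](C)(CCC=C(C)C)/C=C/[C@@H](OC(=O)C=C(C)C)[C@](C)(O)/C=C/C1=O` gives 2950 nM in this assay, and compound 3 `CC(C)=CCC[C@]1(C)/C=C/[C@@H](OC(=O)C=C(C)C)[C@](C)(O)/C=C/C(=O)/C(COC(=O)c2ccc([N+](=O)[O-])cc2)=C\C1` gives 2560 nM. Compound 4 `CC(C)=CCC[C@]1(C)/C=C/[C@@H](OC(=O)C=C(C)C)[C@](C)(O)/C=C/C(=O)/C(C(=O)N(C)C)=C\C1` differs from compound 2 by dimethylcarbamoyl in place of (pyrrolidin-1-yl)methyl on a double-bonded ring carbon. Within the data shown here, the steps that bear on this change are a 21-fold lower number from compound 1 to compound 2 (1.32 log units; beyond the scatter) and an 18-fold higher number from compound 2 to compound 3 (1.26 log units; beyond the scatter): each time the (pyrrolidin-1-yl)methyl group was exchanged for an ester-bearing chain the step was large, while a 1.2-fold lower number from compound 1 to compound 3 (0.06 log units; within the scatter) was small. Compound 4 also gives up the (pyrrolidin-1-yl)methyl group, so the expected step is an 11-fold higher number from compound 2 to compound 4 (1.03 log units; beyond the scatter), a clear rise beyond the scatter. Compound 4 is therefore estimated at 1500 nM, within a range from 400 nM to 5000 nM.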

Compound 4, half-maximal inhibitory concentration: 3670 nM
The estimate for compound 4 lay 2.4-fold (0.39 log units) below the measured number; the measured number falls inside the stated range.
By their numbers in this assay, from the lowest: compound 2; then compounds 3, 1 and 4 (each within the scatter of the next).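

Holding a nitrogen is not enough at this double-bonded ring carbon: dimethylcarbamoyl, which also carries one, gives a 26-fold higher number from compound 2 to compound 4 (1.42 log units; beyond the scatter) in this assay. So far only ester-bearing chains had replaced (pyrrolidin-1-yl)methyl, and this group without an ester stays within the scatter of the acetoxymethyl group, with a 1.2-fold higher number from compound 1 to compound 4 (0.09 log units; within the scatter). No measurement here accounts for the large step. Still open, from the compounds shown here alone, is whether the low number of compound 2 depends on the pyrrolidine ring itself, or whether another amine on the same carbon, such as dimethylaminomethyl or (piperidin-1-yl)methyl, would serve as well.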